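A few compounds are considered here, and "the series" means these few. Any claim that something is new, unique, unknown or untested is made for them only; others in the source may bear on it.

Measured in a functional assay on CHO cells for agonist activity at Free fatty acid receptor 1 (Homo sapiens), read by FLIPR and calcium flux, tested at 100 nM; a lower number here means a weaker effect, a higher number a stronger effect of the compound at the concentration tested:
Compound 1 `O=C(O)CC1COc2cc(OCc3ncc(-c4ccccc4)o3)ccc21` gives 2.34%.
Compound 2 `O=C(O)CC1COc2cc(OCc3csc(-c4ccccc4)n3)ccc21` gives 0.15%.
Compound 3 `Cc1nc(-c2ccc(Cl)s2)sc1COc1ccc2c(c1)OCC2CC(=O)O` gives 8.34%.

Compound 3 carries the largest of these three numbers, but its distance to compound 1 and to compound 2 lies within the usual scatter of this assay, so the three compounds cannot be told apart on the numbers shown; all three sit low in this assay.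

Compound 4 `Cc1nc(-c2ccc(C(F)(F)F)cc2)sc1COc1ccc2c(c1)OCC2CC(=O)O` has not yet been measured in this assay. It differs from compound 3 in one place: 4-(trifluoromethyl)phenyl in place of 5-chlorothiophen-2-yl on an aromatic carbon. No step between measured compounds is shown for a change of this kind, so the expectation for compound 4 rests only on the three low numbers given and on the size of the change. Since compound 3 gives 8.34% and the other two compounds stand within the scatter of it, compound 4 is expected to stay in the same low region, with a step of a number 2.3 percentage points lower from compound 3 to compound 4 (within the scatter) that is expected to be no larger than the scatter, in either direction. The estimate for compound 4 in this assay is 6%, with a range from 0% to 20%.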

Compound 4, a percentage reported as activity, at one concentration (the size of the read-out at that concentration, not a potency): 50.4%
Compound 4: the middle estimate sits 44.4 percentage points below what was measured; measured number outside the range, above it.
By their numbers in this assay, from the lowest: compounds 2, 1 and 3 (each within the scatter of the next); then compound 4.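

The change from 5-chlorothiophen-2-yl to 4-(trifluoromethyl)phenyl gives a number 42.1 percentage points higher from compound 3 to compound 4 (beyond the scatter) in this assay. This is the first step shown that lies beyond the scatter, and it shows that the read-out can respond strongly to the group on this aromatic carbon, next to the ring nitrogen and next to the ring sulfur. The change replaces the ring and its substituent together, so this pair cannot separate the five-membered aromatic ring with 1 hetero atom giving way to a six-membered carbon-only ring from chlorine giving way to trifluoromethyl, and nothing available explains the size of the step.

As far as these compounds go, it remains open whether a 4-chlorophenyl group would behave like the 4-(trifluoromethyl)phenyl group, or whether a nitrile or a methoxy group could take the place of trifluoromethyl. From the compounds shown here alone, with a read-out at a single concentration, the potency of compound 4 also remains open.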